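Swapping the Sulfonyl Aryl Group in a Receptor Binding Series

A few compounds are considered here, and "the series" means these few. Any claim that something is new, unique, unknown or untested is made for them only; others in the source may bear on it.

Among the measured compounds shown here, compound 1 `CC1CCN(c2c(S(=O)(=O)c3cccc(C#N)c3)cnc3cc(Cl)ccc23)CC1` stands highest of the two compounds measured so far in an assay on isolated protein for displacement of a labelled ligand from metabotropic glutamate receptor 5 (Homo sapiens), with a stated time of 60 min, tested at 1 uM; a lower number here means less inhibition, a higher number more inhibition at the concentration tested (going by the name of the read-out): in this assay compound 1 gives 94%. For the measured compounds named here, the only other measured compound, compound 2 `NS(=O)(=O)N1CCN(c2c(S(=O)(=O)c3cccc(F)c3)cnc3cc(F)ccc23)CC1`, differs from compound 1 in several places at once, and in this assay compound 2 gives 1.9%. The gap between these two values lies beyond the scatter, but with so many changes between them it cannot be tied to any one of them.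

Compound 3 `COc1ccc(S(=O)(=O)c2cnc3cc(Cl)ccc3c2N2CCC(C)CC2)cc1Cl` has not yet been measured. It keeps the rest of compound 1 unchanged and differs in one place: 3-chloro-4-methoxyphenyl in place of 3-cyanophenyl on a sulfonyl sulfur. Both the group that leaves and the group that enters are a single six-membered aromatic ring of carbon only with one hydrogen-bond acceptor; the triple bond leaves, while a chlorine and an oxygen enter.

Going by the values given here, no measured pair changes only this group, so the expectation rests on compound 1 alone, whose 94% leaves little room to rise. The expected step in this assay is a number 12 percentage points lower from compound 1 to compound 3 (beyond the scatter), a modest fall or none beyond the scatter. Compound 3 is therefore estimated at 82%, within a range from 50% to 98%.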

Compound 3, a percentage reported as inhibition, at one concentration (the size of the read-out at that concentration, not a potency): 93%
Beside the measured number, compound 3's estimate is 11 percentage points below it; low and high end bracket the measured number.
By their numbers in this assay, from the lowest: compound 2; then compounds 3 and 1 (each within the scatter of the next).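

In this assay, among the compounds shown here, putting 3-chloro-4-methoxyphenyl in place of 3-cyanophenyl on a sulfonyl sulfur gives a number 1 percentage points lower from compound 1 to compound 3 (within the scatter), the first comparison in this set where only one group changes, and it shows that the nitrile is not needed to keep this read-out high in this pair. Both groups are a single six-membered aromatic ring of carbon only with one hydrogen-bond acceptor, and both compounds were read at a single concentration near the top of the percentage scale, so the pair cannot show whether the ring and the acceptor matter or whether the true potencies of the two compounds differ. Nothing measured on these compounds accounts for why the two groups score alike.

Still open, going by these compounds, is how this position responds to a group of a different kind, such as a small methyl, a saturated cyclohexyl, or a phenyl ring carrying an amine or a carboxylic acid. Compound 2 differs from the others in several places at once, so it adds nothing on this question.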